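From 2-oxopyrrolidin-1-yl to 1H-pyrazol-1-yl on a shared core

This account rests on a few compounds, and the source may have more. Where it says the series, first, only, none or still open, it means among the compounds named here.

Of the compounds shown here, three with a shared core have been measured in a functional assay on Huh-7 cells (Homo sapiens) for cytotoxicity, read by MTT assay, with a stated time of 3 days; on this read-out lower numbers stand for higher toxicity in this test and higher numbers for lower toxicity in this test. Compound 1 `CN(Cc1ncnc2c1ncn2[C@@H]1O[C@H](CO)[C@@H](O)[C@H]1O)c1ccccc1` gives 21000 nM. Compound 3 `O=C1CCCN1Cc1ncnc2c1ncn2[C@@H]1O[C@H](CO)[C@@H](O)[C@H]1O` gives 45000 nM, the higher of the two actual numbers, and so the lower toxicity of that pair. Compound 2 `OC[C@H]1O[C@@H](n2cnc3c(CSc4ccccn4)ncnc32)[C@H](O)[C@@H]1O` reads > 100000 nM, which is a limit of the assay and not a number.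

Compound 4 `OC[C@H]1O[C@@H](n2cnc3c(Cn4cccn4)ncnc32)[C@H](O)[C@@H]1O` carries 1H-pyrazol-1-yl in place of 2-oxopyrrolidin-1-yl on a saturated chain carbon bound to an aromatic carbon.

Going by the values given here, the only guides are the measured swaps at this same place. They show a 2.1-fold higher number from compound 1 to compound 3 (0.33 log units; beyond the scatter), an at least 4.7-fold higher number from compound 1 to compound 2 (0.67 log units; beyond the scatter) and an at least 2.2-fold lower number from compound 2 to compound 3 (0.34 log units; beyond the scatter). These steps are modest, two of them rest on a limit, and they do not point one way, so no step beyond the scatter is expected in this assay. The estimated change is a 1.2-fold higher number from compound 3 to compound 4 (0.09 log units; within the scatter). For compound 4 the expected value is 55000 nM, with an estimated range from 25000 nM to 100000 nM.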

Compound 4, half-maximal cytotoxic concentration: > 250000 nM
Compound 4: a limit, no number (the forecaster's own chance of this, stated with the estimate: 30%); middle value at least 4.5-fold (0.65 log units) from the limit.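

In this assay compound 4 gives > 250000 nM, which is a limit of the assay and not a number. Going by these compounds alone, the change from a five-membered non-aromatic ring to a five-membered aromatic ring gives an at least 5.5-fold higher number from compound 3 to compound 4 (0.74 log units; beyond the scatter), and the wider comparison gives an at least 11-fold higher number from compound 1 to compound 4 (1.07 log units; beyond the scatter), the first large step at this position, so the group on this saturated chain carbon can shift toxicity in this test further than the earlier modest steps showed; the step between compound 2 and compound 4 cannot be read, as both values are limits.

An aromatic ring alone does not sort these results, since compound 1 also carries one and has the lowest number of the set. As far as these compounds go, it stays open whether a close relative such as 1H-imidazol-1-yl, or a simple amine, would behave like 1H-pyrazol-1-yl at this place.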